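A few compounds are considered here, and "the series" means these few. Any claim that something is new, unique, unknown or untested is made for them only; others in the source may bear on it.

Compound 1 `CS(=O)(=O)c1ccc(Cc2nnc3n2N=C(c2ccccc2)CS3)cc1`: 51%
Compound 2 `CS(=O)(=O)c1ccc(Cc2nnc3n2N=C(c2ccc(-c4ccccc4)cc2)CS3)cc1`: 60.2%

Among the compounds with values here, in a functional assay on HT-29 cells (Homo sapiens) for cytotoxicity, read by MTT assay, with a stated time of 48 h, tested at 25 uM (a higher number here means a stronger effect of the compound at the concentration tested, a lower number a weaker effect), compound 1 stands lowest of the two numbers, and the one measured step, a number 9.2 percentage points higher from compound 1 to compound 2 (within the scatter), lies within the scatter. Compound 3 `CS(=O)(=O)c1ccc(Cc2nnc3n2N=C(c2cc(Cl)sc2S(N)(=O)=O)CS3)cc1` differs from compound 1 by 5-chloro-2-sulfamoylthiophen-3-yl in place of phenyl on a carbon with a double bond to nitrogen. Within the data shown here, no measured step changes the same group; the only step known replaces a hydrogen by a phenyl elsewhere and is small, so it gives no direction. The step of a number 1 percentage points lower from compound 1 to compound 3 (within the scatter) is therefore expected to stay within the scatter. Compound 3 is estimated at 50%, with a range from 30% to 70%.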

Compound 3, a percentage reported as activity, at one concentration (the size of the read-out at that concentration, not a potency): 18.7%
Estimate against measurement, compound 3: 31.3 percentage points above, and the stated range ends above it.
By their numbers in this assay, from the lowest: compound 3; then compounds 1 and 2 (each within the scatter of the next).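

In this assay, within the data shown here, the carbon with a double bond to nitrogen proves sensitive to what it carries, which the earlier compounds did not show: 5-chloro-2-sulfamoylthiophen-3-yl in place of phenyl gives a number 32.3 percentage points lower from compound 1 to compound 3 (beyond the scatter). Nothing available explains this fall. The compounds shown change the ring, the chlorine and the sulfamoyl group together, so the share of each in the step stays open. From the compounds shown here alone, whether a pyridyl ring or a simple methyl group at this place would keep the read-out near that of compound 1 also stays open.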